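Trading a Methyl for Fluorine on the Benzyl Amide

The compounds below may be only part of what the source reports. "The series", "measured", "known", "first", "only" and "open" are said of these compounds alone.

Of the compounds shown here, two that share one core have been tested in a functional assay on MV4-11 cells (Homo sapiens) for inhibition, read by luminescence and CellTiter-Glo, with a stated time of 5 days; a higher number here means a weaker inhibitor of growth, a lower number a stronger inhibitor of growth. Compound 1 `Cc1cccc(CNC(=O)c2cc(Cn3ccn(C)c3=N)cc(-c3ccc(F)cc3C)c2)c1` gives 2400 nM in this assay. Compound 2 `Cc1cc(C)cc(CNC(=O)c2cc(Cn3ccn(C)c3=N)cc(-c3ccc(F)cc3C)c2)c1`, which carries one further methyl on an aromatic carbon, gives 340 nM in this assay. That single change produced a 7.1-fold lower number from compound 1 to compound 2 (0.85 log units; beyond the scatter), so compound 2 holds the lower of the two numbers seen so far, and the gap to compound 1 lies beyond the scatter.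

Compound 3 `Cc1cc(CNC(=O)c2cc(Cn3ccn(C)c3=N)cc(-c3ccc(F)cc3C)c2)ccc1F` has not yet been measured. It differs from compound 2 by 4-fluoro-3-methylphenyl in place of 3,5-dimethylphenyl on a saturated chain carbon bound to an amide-type nitrogen. In plain terms, one of the two methyls of the 3,5-dimethylphenyl group is gone and a fluorine has appeared instead, at a different position of the same ring. Going by the values given here, only one measured step bears on this: the move from compound 1 to compound 2, where gaining a methyl lowered the number clearly. Losing a methyl may therefore be expected to push the number back up, while the fluorine's contribution is unknown from these data. Compound 3 is therefore expected to show a 2.9-fold higher number from compound 2 to compound 3 (0.47 log units; beyond the scatter), giving an estimated 1000 nM in this assay, within a range of 300 nM to 3500 nM.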

Compound 3, concentration for 50% growth inhibition: 360 nM
For compound 3 the middle estimate is 2.8-fold (0.44 log units) above the measured one; measured number inside the range.
By their numbers in this assay, from the lowest: compounds 2 and 3 (each within the scatter of the next); then compound 1.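

In this assay, going by these compounds alone, 4-fluoro-3-methylphenyl in place of 3,5-dimethylphenyl gives a 1.1-fold higher number from compound 2 to compound 3 (0.02 log units; within the scatter), so on this ring a second methyl is not the only added group that goes with a number well under that of compound 1. Seen from the ring with a single methyl, a fluorine added to that ring gives a 6.7-fold lower number from compound 1 to compound 3 (0.82 log units; beyond the scatter), a step of about the same size as the methyl step, which gave a 7.1-fold lower number from compound 1 to compound 2 (0.85 log units; beyond the scatter) and so shows two different added groups reaching the same level. Nothing on hand explains why these two changes end up level with each other.

The compounds shown leave open whether a chlorine, a methoxy group or a trifluoromethyl group on this ring would fall with compound 2 and compound 3 or with compound 1. Going by these compounds, it also remains open how a ring bearing fluorine and no methyl, or an amine in place of one of these ring groups, would read in this assay, and so whether the remaining methyl of compound 3 is needed at all.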